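Hydrogen in place of fluoro on compound 3

The source may report more compounds than this note shows. Statements on the series, on what has been measured and on what is new or still open speak of the compounds shown alone.

Compound 1 `CC(C)(C)c1ccc(C(=O)NNc2c(Br)cccc2Br)cc1` gives > 100000 nM as a limit
Compound 2 `COc1cccc(C(=O)NNc2c(Br)cccc2Br)c1` gives > 100000 nM as a limit
Compound 3 `O=C(NNc1c(Br)cccc1Br)c1ccc(F)cc1` gives > 100000 nM as a limit

In a toxicity assay on MDCK cells (Canis lupus familiaris) for cytotoxicity, read by CCK-8 assay, with a stated time of 48 h (on this read-out lower numbers stand for higher toxicity in this test and higher numbers for lower toxicity in this test), compound 3 gives > 100000 nM as a limit and not as a number. The picture so far is the limit of > 100000 nM in this assay, at which 3 of the 3 values shown sit, and nothing finer can be read from it. Compound 4 `O=C(NNc1c(Br)cccc1Br)c1ccccc1` differs from compound 3 by hydrogen in place of fluoro on an aromatic carbon with hydrogen in place of fluoro on an aromatic carbon. Among the compounds with values here, the only measured step at this place is a step that the two limits leave unreadable from compound 1 to compound 3 and it offers no size to go on. With compound 3 at > 100000 nM as a limit, no step beyond the scatter is expected in this assay for this change. The expected step is a step that the limit leaves unreadable from compound 3 to compound 4 on this reading. Expected for compound 4 is 120000 nM within an estimated range from 60000 nM to 300000 nM and most likely reported only as a limit.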

Compound 4, half-maximal cytotoxic concentration: > 100000 nM
Compound 4: only a limit was reported; the forecaster's own chance of this, stated with the estimate: 90%; the middle value does not contradict the limit.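

In this assay compound 4 also gives only a limit, so its steps from compound 1, compound 2 and compound 3 cannot be read. The compounds shown leave open whether any of these substituents changes the half-maximal cytotoxic concentration, since all share one limit: the limit of > 100000 nM in this assay, at which 4 of the 4 values shown sit.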